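The source may hold more compounds than are shown below. What is called first, only, known or untested is meant among the compounds shown, and "the series" means these compounds.

Compound 1 `CCCN1CCN(c2ccc(S(=O)(=O)Oc3ccccc3C)cc2)C1=O` gives > 100000 nM in a functional assay on MCF7 cells (Homo sapiens) for antiproliferative activity, read by sulforhodamine B assay, with a stated time of 48 h (a higher number here means a weaker inhibitor, a lower number a stronger inhibitor), which is a limit of the assay and not a number. Within the data shown here, compound 2 `CCCN1CCN(c2ccc(S(=O)(=O)Oc3cccc(F)c3)cc2)C1=O` gives 24000 nM in this assay, the only true number so far. Compound 3 `CCCN1CCN(c2ccc(S(=O)(=O)Oc3ccc(C)cc3)cc2)C1=O` keeps the shared core and carries 4-methylphenyl in place of 3-fluorophenyl on the oxygen bound to the sulfonyl sulfur (4-methylphenyl in place of 3-fluorophenyl on an oxygen). Among the measured compounds shown here, one measured step bears on this place: an at least 4.1-fold lower number from compound 1 to compound 2 (0.61 log units; beyond the scatter). As far as these compounds go, its full size is unknown because of the limit of > 100000 nM in this assay, at which 1 of the 2 values shown sits. That step also starts from 2-methylphenyl, not 4-methylphenyl, so it gives only loose guidance for compound 3. The step expected in this assay is a 1.3-fold higher number from compound 2 to compound 3 (0.10 log units; within the scatter), which means none beyond the scatter, with a slight lean towards a higher number. For compound 3 the estimated value is 30000 nM, with an expected range of 10000 nM to 90000 nM.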

Compound 3, half-maximal inhibitory concentration: 64000 nM
Estimate against measurement, compound 3: 2.1-fold (0.33 log units) below; the range from low to high includes it.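

In this assay, this position on the oxygen bound to the sulfonyl sulfur now gives a comparison between two true numbers: 4-methylphenyl in place of 3-fluorophenyl gives a 2.7-fold higher number from compound 2 to compound 3 (0.43 log units; beyond the scatter) and so shows a modest loss. 4-methylphenyl in place of 2-methylphenyl gives an at least 1.5-fold lower number from compound 1 to compound 3 (0.19 log units; that floor lies within the scatter) and so gives no firm separation between the two methylphenyl compounds. Compound 1 remains a limit and not a number: the limit of > 100000 nM in this assay, at which 1 of the 3 values shown sits.

The step from compound 2 to compound 3 changes both the substituent and its place on the ring, so it cannot show which of the two matters. Readings for 3-methylphenyl and 4-fluorophenyl would separate those two changes, and how an amine or a carboxylic acid on this ring would read also remains open.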